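Fluorine to chlorine on the anilino ring of a cinnamamide

This account rests on a few compounds, and the source may have more. Where it says the series, first, only, none or still open, it means among the compounds named here.

Measured so far:
compound 1 `O=C(/C=C/c1ccccc1)Nc1cc2ncnc(Nc3ccc(F)c(Cl)c3)c2s1`: 6670 nM
compound 2 `O=C(/C=C/c1ccccc1)Nc1cc2c(Nc3cccc(Cl)c3F)ncnc2s1`: 26200 nM
compound 3 `O=C(/C=C/c1ccccc1)Nc1cc2c(Nc3cc(Cl)cc(Cl)c3)ncnc2s1`: 40 nM

The three compounds share one core and differ only in the substituted phenyl on the ring nitrogen. In a functional assay on A549 cells (Homo sapiens) for antiproliferative activity, read by MTT assay, with a stated time of 48 h (a higher number here means a weaker inhibitor, a lower number a stronger inhibitor), compound 1 gives 6670 nM, the second highest of the three numbers; compound 2 sits higher, beyond the scatter, and compound 3 lies far below it. For the measured compounds named here, the one measured step, a 660-fold lower number from compound 2 to compound 3 (2.82 log units; beyond the scatter), swaps the whole substitution pattern of that phenyl and is therefore only loosely related to the present change.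

Compound 4 `O=C(/C=C/c1ccccc1)Nc1cc2ncnc(Nc3ccc(Cl)c(Cl)c3)c2s1` differs from compound 1 by chloro in place of fluoro on an aromatic carbon, on an aromatic carbon of a six-membered aromatic ring of carbon only, ortho to a chloro group and para to a large group. Going by the values given here, no measured pair isolates a chloro-for-fluoro exchange, so the step is estimated to be small, tending toward a lower number. Compound 4 is therefore expected to reach about 4000 nM (range 1000 nM to 15000 nM), an expected step of a 1.7-fold lower number from compound 1 to compound 4 (0.22 log units; within the scatter).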

Compound 4, half-maximal inhibitory concentration: 19500 nM
Compound 4: the middle estimate sits 4.9-fold (0.69 log units) below what was measured, outside the stated range (above it).
By their numbers in this assay, from the lowest: compound 3; then compound 1; then compounds 4 and 2 (each within the scatter of the next).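

In this assay, putting chloro in place of fluoro on this aromatic carbon, ortho to a chloro group and para to a large group, gives a 2.9-fold higher number from compound 1 to compound 4 (0.47 log units; beyond the scatter) and so counts as a modest step. This is the first pair shown in which a single halogen atom is the only difference, and it shows that this one carbon can shift the number on its own, with chloro giving the weaker inhibitor of the two in this pair. No measurement is available here that explains the shift.

From the compounds shown here alone, whether bromo or methoxy on the same carbon would raise the number further or bring it back down remains open, as does the result with plain hydrogen there. Also open, going by these compounds, is whether the exchange would move the number the same way in a phenyl ring without the neighbouring chloro group.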